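From a cyano group to a hept-1-yn-1-yl chain

The source may report more compounds than this note shows. Statements on the series, on what has been measured and on what is new or still open speak of the compounds shown alone.

This account follows three measured compounds and one that is not yet measured, all examined in an ADME assay on L1210/0 cells (Mus musculus) for cytotoxicity, with a stated time of 48 h; a lower number here means a stronger inhibitor, a higher number a weaker inhibitor. Compound 1 `CC(=O)OCCOCn1cnc2c(S)nc(F)nc21` is the only one of the three with a number: in this assay compound 1 gives 40000 nM. Compound 2 `CCOc1ncnc2c1ncn2C[C@@H]1C[C@H](CO)c2ccccc21` reaches no number; in this assay compound 2 gives only the limit > 200000 nM. Compound 3 `N#Cc1cn([C@H]2C[C@H](O)[C@@H](CO)O2)c(=O)[nH]c1=O` likewise stops at a limit; in this assay compound 3 gives > 200000 nM. Compound 3 therefore stands on no number at all, and it shares that position with another compound, because the limit of > 200000 nM in this assay, at which 2 of the 3 values shown sit, is where two of the three values sit. Among the compounds with values here, no pair among the measured compounds differs in one place, so no measured step can be drawn from them.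

Compound 4 `CCCCCC#Cc1cn([C@H]2C[C@H](O)[C@@H](CO)O2)c(=O)[nH]c1=O` differs from compound 3 in one place: hept-1-yn-1-yl in place of cyano on an aromatic carbon. Within the data shown here, with no measured step to lean on, the size and direction of the change in this assay can only be guessed; the writer expects a move toward stronger inhibition, large enough to leave the limit behind, though a second limit would not be surprising. Compound 4 is estimated at 20000 nM, within 3000 nM to 200000 nM, which means an expected step of an at least 10-fold lower number from compound 3 to compound 4 (1.00 log units; beyond the scatter).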

Compound 4, half-maximal inhibitory concentration: > 200000 nM
Compound 4 ended at the assay's limit; the forecaster's own chance of this, stated with the estimate: 30%; middle value at least 10-fold (1.00 log units) away from the limit.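

Compound 3 and compound 4 both stop at a limit in this assay, so hept-1-yn-1-yl in place of cyano yields no readable step, and compound 4 joins the values held there: the limit of > 200000 nM in this assay, at which 3 of the 4 values shown sit.

The compounds shown leave open whether this exchange on an aromatic carbon moves the number in either direction at all.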